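The source may report more compounds than this note shows. Statements on the series, on what has been measured and on what is new or still open speak of the compounds shown alone.

Measured so far in a physicochemical assay for solubility, using the shake flask method, measured as kinetic solubility, with a stated time of 20 h, at pH 2; a lower number here means a less soluble compound, a higher number a more soluble compound:
- compound 1 `COc1ccnc(Nc2cc3[nH]c(-c4cccc(C(F)(F)F)c4)nc3cn2)c1`: < 5000 nM (a limit, not a number)
- compound 2 `FC(F)(F)c1cccc(-c2nc3cnc(Nc4ncccn4)cc3[nH]2)c1`: 155000 nM
- compound 3 `FC(F)(F)c1ccc(Nc2cc3[nH]c(-c4cccc(C(F)(F)F)c4)nc3cn2)nc1`: < 5000 nM (a limit, not a number)

Compound 3 stands at the limit of < 5000 nM in this assay, at which 2 of the 3 values shown sit, so it has a limit and no actual number. Compound 4 `FC1(F)CCC(c2nc3cnc(Nc4ccc(C(F)(F)F)cn4)cc3[nH]2)C1` differs from it in one place: 3,3-difluorocyclopentyl, a non-aromatic ring, replaces 3-(trifluoromethyl)phenyl on an aromatic carbon (3,3-difluorocyclopentyl in place of 3-(trifluoromethyl)phenyl on an aromatic carbon). For the measured compounds named here, no measured step touches that carbon. All three measured steps change the group on a nitrogen instead. They include an at least 31-fold higher number from compound 1 to compound 2 (1.49 log units; beyond the scatter) and an at least 31-fold lower number from compound 2 to compound 3 (1.49 log units; beyond the scatter), both large, and also a step that the two limits leave unreadable from compound 1 to compound 3. Going by the values given here, these steps show only that one change can move this assay a long way, so they give a weak guide to size and direction. A modest rise is therefore expected, held with little confidence, and the reading may again be only a limit. The expected change is an at least 2.4-fold higher number from compound 3 to compound 4 (0.38 log units; beyond the scatter). For compound 4 the estimated value is 12000 nM, with an expected range from 3000 nM to 60000 nM.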

Compound 4, solubility: 185000 nM
Compound 4: the middle estimate sits 15-fold (1.19 log units) below what was measured; measured number above the stated range.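

In this assay, putting 3,3-difluorocyclopentyl in place of 3-(trifluoromethyl)phenyl on the aromatic carbon between two ring nitrogen atoms gives an at least 37-fold higher number from compound 3 to compound 4 (1.56 log units; beyond the scatter). For the compounds shown here, the earlier steps changed only the group on a nitrogen, so this is the first sign that this carbon can also move the read-out a long way. The change also lifts a compound that keeps 5-(trifluoromethyl)pyridin-2-yl on the nitrogen off the limit, and compound 3 itself has only a limit, not a number: the limit of < 5000 nM in this assay, at which 2 of the 4 values shown sit.

In this one step the aromatic ring goes, the ring size changes and the fluorine count changes all at once, and the compounds shown do not separate these. On these data alone, how a plain cyclopentyl or a piperidine would read at this carbon remains open.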